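Removing a Ring Hydroxy from Compound 2

The source may hold more compounds than are shown below. What is called first, only, known or untested is meant among the compounds shown, and "the series" means these compounds.

Growth inhibition measured in a functional assay on HL-60 cells (Homo sapiens) for inhibition, read by MTT assay, with a stated time of 48 h, tested at 10 uM; on this read-out higher numbers stand for more inhibition of growth at the one concentration tested and lower numbers for less inhibition of growth:
- compound 1 `Cc1cc(=O)c2c(O)c(CN(C)CC(=O)O)c(O)c([C@H]3CCN(C)C[C@H]3O)c2o1`: 23%
- compound 2 `Cc1cc(=O)c2c(O)c(CN3CC(O)CC3C(=O)O)c(O)c([C@H]3CCN(C)C[C@H]3O)c2o1`: 28%

Going by the values given here, compound 2 has only one measured neighbour, and the two numbers cannot be told apart. That single measured step reads a number 5 percentage points higher from compound 1 to compound 2 (within the scatter).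

The next compound, compound 3 `Cc1cc(=O)c2c(O)c(CN3CCCC3C(=O)O)c(O)c([C@H]3CCN(C)C[C@H]3O)c2o1`, changes compound 2 at one place: hydrogen in place of hydroxy on a saturated ring carbon. In words, this is hydrogen in place of hydroxy on a saturated ring carbon, turning 2-carboxy-4-hydroxypyrrolidin-1-yl into 2-carboxypyrrolidin-1-yl.

Among the compounds with values here, no measured pair changes this hydroxy alone, so the one step above is the only guide, and it stayed within the scatter. No shift beyond the scatter is therefore expected in this assay. The expected change is a number 2 percentage points lower from compound 2 to compound 3 (within the scatter). For compound 3 the estimated value is 26%, with an expected range from 14% to 38%.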

Compound 3, percent growth inhibition at one concentration: 16%
Beside the measured number, compound 3's estimate is 10 percentage points above it; the measured number falls inside the stated range.
By their numbers in this assay, from the lowest: compounds 3, 1 and 2 (each within the scatter of the next, the first and the last beyond it).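

Going by these compounds alone, of the changes seen so far, this is the first to move the number beyond the usual scatter. Replacing the ring hydroxy with hydrogen gives a number 12 percentage points lower from compound 2 to compound 3 (beyond the scatter), so in this assay this one hydroxy on the saturated ring makes a modest but readable difference. The ring without the hydroxy is a different matter: swapping the open (carboxymethyl)(methyl)amino group for 2-carboxypyrrolidin-1-yl gives a number 7 percentage points lower from compound 1 to compound 3 (within the scatter), so the ring alone does not separate from the open chain.

The compounds shown leave open whether a methoxy group, an amine or a fluorine atom on the same ring carbon would match the hydroxy or fall to the level of hydrogen. Nothing available explains why the hydroxy makes this difference.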